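This account rests on a few compounds, and the source may have more. Where it says the series, first, only, none or still open, it means among the compounds named here.

Measured compounds in a functional assay on MCF7 cells (Homo sapiens) for antiproliferative activity, read by MTT assay, with a stated time of 72 h; a lower number here means a stronger inhibitor, a higher number a weaker inhibitor:

compound 1 `CC1=CC[C@H]2[C@@H]1CC=C(C)[C@@H](CC[C@H]1[C@]3(C)CC[C@H](O)C(C)(C)O[C@H]3CC[C@@]1(C)O)C2(C)C`; for compound 1 the reading is a limit of the assay, > 50000 nM.
compound 2 `CC1=CC[C@H]2[C@@H]1CC=C(C)[C@@H](CCC1=C(C)CC[C@@H]3OC(C)(C)[C@@H](O)CC[C@@]13C)C2(C)C`; for compound 2 the reading is likewise a limit, > 50000 nM.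
compound 3 `CC1=CC[C@H]2[C@H](CC[C@]2(C)O)C(C)(C)[C@@H]1CC[C@H]1[C@]2(C)CC[C@H](OCc3ccccc3)C(C)(C)O[C@H]2CC[C@@]1(C)O`; for compound 3 the reading is again a limit, > 50000 nM.

Compound 3 therefore stands nowhere in particular on the numbers shown: none of the three compounds gives a number at all, and all three sit at the limit of > 50000 nM in this assay, at which 3 of the 3 values shown sit. Going by the values given here, no step between measured compounds can be read, since no pair differs in one place.

Compound 4 `CC1=CC[C@H]2[C@H](CC[C@]2(C)O)C(C)(C)[C@@H]1CC[C@H]1[C@]2(C)CC[C@H](OC(=O)c3cccc(C(F)(F)F)c3)C(C)(C)O[C@H]2CC[C@@]1(C)O` is the next member. It differs from compound 3 in one place: (3-(trifluoromethyl)phenyl)carbonyl in place of benzyl on an oxygen on a saturated carbon. The ester built on the same oxygen carries a trifluoromethyl on its aromatic ring, where compound 3 carried a plain benzyl.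

Among the compounds with values here, with three members at the limit and no measured step to lean on, the expected step that the limit leaves unreadable from compound 3 to compound 4 is none that can be told from the limit; the most likely outcome for compound 4 is another reading at the limit. Compound 4 is accordingly estimated at 60000 nM, with a range from 15000 nM to 200000 nM.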

Compound 4, half-maximal inhibitory concentration: 37900 nM
Estimate against measurement, compound 4: 1.6-fold (0.20 log units) above, within the range that was stated.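

In this assay, going by these compounds alone, compound 4 gives 37900 nM, the first reading that is a number and not a limit, so the group on this oxygen on a saturated carbon now has a number on one side of a step. On these data alone, exchanging benzyl for (3-(trifluoromethyl)phenyl)carbonyl gives an at least 1.3-fold lower number from compound 3 to compound 4 (0.12 log units; that floor lies within the scatter); this is only a floor, and the true size of the step remains unknown. The rest of the series still offers no number to set beside compound 4: the limit of > 50000 nM in this assay, at which 3 of the 4 values shown sit.

Whether the carbonyl or the trifluoromethyl accounts for the reading stays open, since both enter together; a plain benzoyl and a benzyl carrying trifluoromethyl on the same oxygen would separate them. Also open, as far as these compounds go, is how an amine or a carboxylic acid on the aromatic ring of this ester would read in this assay.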